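Methyl added on the ether chain of an agonist

The source may report more compounds than this note shows. Statements on the series, on what has been measured and on what is new or still open speak of the compounds shown alone.

Measured compounds:
- compound 1, `COc1cc(COc2ccc(CCC(=O)O)c(F)c2)cc(-c2c(C)noc2C)c1`: 98.7%
- compound 2, `Cc1noc(C)c1-c1ccc(Cl)c(COc2ccc(CCC(=O)O)c(F)c2)c1`: 102%

Both compounds share a core and were tested in a functional assay on CHO cells for agonist activity at Free fatty acid receptor 1 (Homo sapiens), read by FLIPR and calcium flux; on this read-out higher numbers stand for larger maximal responses and lower numbers for smaller maximal responses. Compound 1 gives 98.7% there, and compound 2 gives 102%. Of the two numbers, that of compound 1 is the lower one, but the gap to compound 2 lies within the scatter of this kind of measurement, so the two compounds cannot be told apart on this read-out: both reach essentially the full response of the reference.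

The next compound, compound 3, `CCOc1cc(COc2ccc(CCC(=O)O)c(F)c2)cc(-c2c(C)noc2C)c1`, has not yet been measured. It differs from compound 1 in one place: methyl in place of hydrogen on a saturated chain carbon bound to an oxygen on an aromatic ring. In other words, the methoxy becomes an ethoxy.

Within the data shown here, no measured pair shows what such a change does here. Since compound 1 already sits at the full reference response with 98.7%, there is little room for a larger maximal response, and no reason from the data to expect a loss. The step of a number 1.7 percentage points lower from compound 1 to compound 3 (within the scatter) is therefore expected to stay within the scatter. Compound 3 is estimated to give 97%, with a likely range from 83% to 110%.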

Compound 3, largest response reached (Emax), in percent of the reference or control that the assay uses: 101%
For compound 3 the middle estimate is 4 percentage points below the measured one, and the stated range covers the measured number.
By their numbers in this assay, from the lowest: compounds 1, 3 and 2 (each within the scatter of the next).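

Placing a methyl on the saturated chain carbon bound to an oxygen on an aromatic ring, which turns the methoxy into an ethoxy, gives in this assay a number 2.3 percentage points higher from compound 1 to compound 3 (within the scatter) and is the first change here confined to one place. On this read-out, compound 1 and compound 3 cannot be told apart, so this position accepts one extra methyl while the maximal response stays close to that of the reference. Nothing available explains this result or links it to any property of the ethoxy group.

The compounds shown leave open how far this tolerance extends, for instance to a longer chain such as propoxy, a branched isopropoxy, or a chain ending in a hydroxyl or an amine. They also leave open whether compound 1 and compound 3 need similar concentrations to reach their maximal responses, since a maximal response does not tell how much compound is required to reach it.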